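This account rests on a few compounds, and the source may have more. Where it says the series, first, only, none or still open, it means among the compounds named here.

Measured in a functional assay on PC-3 cells (Homo sapiens) for inhibition, read by CellTiter-Glo, with a stated time of 72 h; a lower number here means that less compound is tolerated, a higher number that more compound is tolerated:

- Compound 1 `CC1=C(CC(=O)NCCN(C)C)c2cc(F)ccc2/C1=C\c1ccc(S(C)(=O)=O)cc1`: > 50000 nM, a limit of the assay and not a number
- Compound 2 `CC1=C(CC(=O)N2CCN(CCCN(C)C)CC2)c2cc(F)ccc2/C1=C\c1ccc([S+](C)[O-])cc1`: > 50000 nM, also a limit
- Compound 3 `CC1=C(CC(=O)N2CCN(c3ccncc3)CC2)c2cc(F)ccc2/C1=C\c1ccc([S+](C)[O-])cc1`: 21900 nM

Within the data shown here, compound 3, at 21900 nM, holds the only true number in this small set. The other two entries are limits, as the limit of > 50000 nM in this assay, at which 2 of the 3 values shown sit, shows.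

The next compound is compound 4 `CC1=C(CC(=O)N2CCN(c3ccncc3)CC2)c2cc(F)ccc2/C1=C\c1nc2ccccc2s1`, which differs from compound 3 in a single group: a group of 9 heavy atoms (7 carbon, 1 nitrogen, 1 sulfur; one five-membered aromatic ring with 2 hetero atoms, one six-membered aromatic ring of carbon only) in place of a group of 9 heavy atoms (7 carbon, 1 oxygen, 1 sulfur; one six-membered aromatic ring of carbon only), on a double-bonded chain carbon bound to a double-bonded ring carbon. The group that enters is 1,3-benzothiazol-2-yl, and the pyridin-4-yl of compound 3 stays in place.

Among the measured compounds shown here, only one measured step is available, and that is an at least 2.2-fold lower number from compound 2 to compound 3 (0.35 log units; beyond the scatter). It replaced 3-(dimethylamino)propyl with pyridin-4-yl, which is a different part of the molecule from the group changing now. For the measured compounds named here, it therefore gives no direct size or direction for this change, and no measured pair shows a swap at this place. With so little to go on, the expectation in this assay is no shift beyond the scatter.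

The expected step is a 1.4-fold lower number from compound 3 to compound 4 (0.14 log units; within the scatter). The range has to stay wide because the limit of > 50000 nM in this assay, at which 2 of the 3 values shown sit, leaves little measured ground.

For compound 4 the estimated value is 16000 nM, with an expected range from 4000 nM to 50000 nM.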

Compound 4, half-maximal cytotoxic concentration: 12300 nM
Beside the measured number, compound 4's estimate is 1.3-fold (0.11 log units) above it, and the stated range covers the measured number.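

Among the compounds shown, this is the only measured swap on the double-bonded chain carbon bound to a double-bonded ring carbon, and this assay gives a 1.8-fold lower number from compound 3 to compound 4 (0.25 log units; within the scatter) and so does not separate the two compounds. Replacing the group with one six-membered aromatic ring by 1,3-benzothiazol-2-yl, which has the same number of heavy atoms but adds a five-membered aromatic ring and carries nitrogen where the old group carried oxygen, therefore produces no shift that can be told from ordinary repeat variation, with pyridin-4-yl kept in place on the ring amine nitrogen. This reading rests on one pair with real numbers on both sides, and such numbers are scarce in this set: the limit of > 50000 nM in this assay, at which 2 of the 4 values shown sit.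

From the compounds shown here alone, whether the same holds for a plain phenyl ring, or for a ring carrying a carboxylic acid or an amine, remains open at this place. Also open, going by these compounds, is whether 1,3-benzothiazol-2-yl would give a real number with 3-(dimethylamino)propyl in place of pyridin-4-yl, or with a longer chain on that ring nitrogen.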